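From trifluoromethyl to fluoro on compound 2

A few compounds are considered here, and "the series" means these few. Any claim that something is new, unique, unknown or untested is made for them only; others in the source may bear on it.

Measured in a physicochemical assay for solubility, read by HPLC, using the shake flask method, in phosphate buffer, measured as kinetic solubility, with a stated time of 20 h, at pH 6.5; a lower number here means a less soluble compound, a higher number a more soluble compound:
- Compound 1 `Fc1ccc(Nc2cc3[nH]c(Nc4cc(N5CCNCC5)ccn4)nc3cn2)cc1C(F)(F)F`: 95000 nM
- Compound 2 `O=C(c1ccnc(Nc2nc3cnc(Nc4ccc(F)c(C(F)(F)F)c4)cc3[nH]2)c1)N1CCN(C2CC2)CC1`: < 5000 nM (a limit, not a number)
- Compound 3 `C[C@@H]1CN(C(=O)c2ccnc(Nc3nc4cnc(Nc5ccc(F)c(C(F)(F)F)c5)cc4[nH]3)c2)C[C@H](C)N1`: 200000 nM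

On these numbers, compound 2 is known only by its limit of < 5000 nM. This is the limit of < 5000 nM in this assay, at which 1 of the 3 values shown sits. Compound 4 `O=C(c1ccnc(Nc2nc3cnc(Nc4ccc(F)c(F)c4)cc3[nH]2)c1)N1CCN(C2CC2)CC1` differs from it by fluoro in place of trifluoromethyl on an aromatic carbon. Going by the values given here, no measured step touches that place. The measured steps, an at least 19-fold lower number from compound 1 to compound 2 (1.27 log units; beyond the scatter), a 2.1-fold higher number from compound 1 to compound 3 (0.32 log units; beyond the scatter) and an at least 40-fold higher number from compound 2 to compound 3 (1.60 log units; beyond the scatter), all exchange the piperazine group instead, so they bear only indirectly: two are large and one modest. The expected change is small and upward, an at least 1.2-fold higher number from compound 2 to compound 4 (0.07 log units; that floor lies within the scatter). The estimated value for compound 4 is 6000 nM, with an expected range from 1500 nM to 30000 nM.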

Compound 4, solubility: < 5000 nM
Compound 4 ended at the assay's limit (the forecaster's own chance of this, stated with the estimate: 45%); middle value at least 1.2-fold (0.07 log units) away from the limit.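

Going by these compounds alone, compound 2 and compound 4 both stand at a limit, not a number, in this assay, and no step between them can be read. From the compounds shown here alone, what fluoro in place of trifluoromethyl changes in this assay remains open.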